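The source may hold more compounds than are shown below. What is called first, only, known or untested is meant among the compounds shown, and "the series" means these compounds.

Compound 1 `CN1CCN(c2ccc(-c3cc(=O)c4c(O)c(O)c(O)cc4o3)cc2)CC1` was tested in a toxicity assay on Huh-7 cells (Homo sapiens) for cytotoxicity, read by CCK-8 assay, with a stated time of 24 h (on this read-out higher numbers stand for lower toxicity in this test and lower numbers for higher toxicity in this test), and gave > 100000 nM, which is a limit of the assay rather than a measured number. Compound 2 `O=c1cc(-c2ccccc2)oc2c(-c3cc(F)cc(F)c3)c(O)c(O)c(O)c12` likewise gave > 100000 nM in this assay, again only a limit. Compound 3 `Oc1c(O)c(O)c2c(=S)cc(-c3ccccc3)oc2c1-c1ccc(F)cc1` gave > 100000 nM in this assay, also a limit. Compound 1 therefore stands exactly where the other two stand: the limit of > 100000 nM in this assay, at which 3 of the 3 values shown sit. Compound 4 `O=c1cc(-c2ccc(Nc3ccc(F)cc3)cc2)oc2cc(O)c(O)c(O)c12` has not yet been measured. Its difference from compound 1 is (4-fluorophenyl)amino in place of 4-methylpiperazin-1-yl on an aromatic carbon, the new group entering para to a large group. For the measured compounds named here, with no measured step between any two compounds to draw on, the expectation is that a step that the limit leaves unreadable from compound 1 to compound 4 stays within the usual scatter. Compound 4 is thus expected to give 150000 nM, with a range from 50000 nM to 500000 nM, most probably reported once more as a limit.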

Compound 4, half-maximal cytotoxic concentration: > 100000 nM
Compound 4 was reported as a limit; the forecaster's own chance of this, stated with the estimate: 80%; the middle value is on the limit's open side.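

Compound 1 and compound 4 are both reported only as limits, so no step between them can be read, and all the compounds shown stand at the same place: the limit of > 100000 nM in this assay, at which 4 of the 4 values shown sit.

The compounds shown leave open what concentration, if any, is toxic to these cells in this assay.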